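The source may hold more compounds than are shown below. What is called first, only, known or untested is meant among the compounds shown, and "the series" means these compounds.

Measured in a functional assay on MCF7 cells (Homo sapiens) for antiproliferative activity, read by MTT assay, with a stated time of 72 h; a lower number here means a stronger inhibitor, a higher number a weaker inhibitor:
- compound 1 `O=C(N/N=C/c1ccc(F)cc1)Nc1ccc(Oc2ccnc3[nH]ccc23)cc1`: 3720 nM
- compound 2 `O=C(N/N=C/c1ccc([N+](=O)[O-])cc1)Nc1ccc(Oc2ccnc3[nH]ccc23)cc1`: 15600 nM

Compound 2 has the higher of the two numbers, at 15600 nM. Compound 3 `O=C(N/N=C/c1cccc(Cl)c1Cl)Nc1ccc(Oc2ccnc3[nH]ccc23)cc1` carries 2,3-dichlorophenyl in place of 4-nitrophenyl on a carbon with a double bond to nitrogen. Among the measured compounds shown here, one measured step bears on this: a 4.2-fold higher number from compound 1 to compound 2 (0.62 log units; beyond the scatter), with nitro in place of fluoro on an aromatic carbon. For the measured compounds named here, no dichlorophenyl compound has been measured, so this guide is loose. With the nitro group gone, a move of similar size toward a lower number is expected in this assay. The expected step is a 2.8-fold lower number from compound 2 to compound 3 (0.45 log units; beyond the scatter). For compound 3 the estimated value is 5500 nM, with an expected range of 1800 nM to 16000 nM.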

Compound 3, half-maximal inhibitory concentration: "not active" (no number reported)
The entry for compound 3 holds no number, and the estimate cannot be compared.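

Among the compounds shown here, compound 3 is reported as "not active" in this assay, with no number, so no step from compound 2 to compound 3 can be read. As far as these compounds go, how far 2,3-dichlorophenyl shifts the value relative to 4-nitrophenyl remains open. No evidence at hand bears on this result.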